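Swapping the Aryl Group on a Spirocyclic Sigma Ligand

This account rests on a few compounds, and the source may have more. Where it says the series, first, only, none or still open, it means among the compounds named here.

Of the compounds shown here, two have so far been tested in an assay on membranes from brain for displacement of a labelled ligand from Sigma non-opioid intracellular receptor 1 (Cavia porcellus), read by scintillation counting, with a stated time of 120 min; on this read-out higher numbers stand for weaker inhibition and lower numbers for stronger inhibition. Compound 1 `O=[N+]([O-])c1ccc(-c2scc3c2CCOC32CCN(Cc3ccccc3)CC2)cc1` gives 1.7 nM. Compound 2 `COc1ccc(-c2cc3c(s2)C2(CCN(Cc4ccccc4)CC2)OC(OC)C3)cc1` gives 56 nM, which is the higher of the two numbers, and its gap to compound 1 lies beyond the usual scatter of this assay; the two compounds differ in several places at once, so no single change can be credited for that gap.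

Compound 3 `COC1Cc2cc(-c3cccnc3)sc2C2(CCN(Cc3ccccc3)CC2)O1` has not yet been measured. It differs from compound 2 in one place: pyridin-3-yl in place of 4-methoxyphenyl on an aromatic carbon. Among the compounds with values here, no measured pair isolates this kind of swap, so any expectation rests on compound 2 alone. The step from compound 2 to compound 3 is expected to be a 2.0-fold higher number from compound 2 to compound 3 (0.29 log units; within the scatter), a modest move toward a higher number that may not clearly exceed the scatter. Compound 3 is therefore estimated at 110 nM, with a likely range from 30 nM to 400 nM.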

Compound 3, inhibition constant: 2.5 nM
For compound 3 the middle estimate is 44-fold (1.64 log units) above the measured one, outside the stated range (below it).
By their numbers in this assay, from the lowest: compounds 1 and 3 (each within the scatter of the next); then compound 2.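

In this assay, the aryl group on this aromatic carbon, next to the ring sulfur, has a strong effect on the read-out: pyridin-3-yl in place of 4-methoxyphenyl gives a 22-fold lower number from compound 2 to compound 3 (1.35 log units; beyond the scatter), a large step beyond the scatter. The rest of the molecule stays the same, and the two groups have equal counts of hydrogen-bond donors and acceptors, so those counts do not separate them. Nothing available here explains why this swap has such a large effect.

This one swap removes the methoxy group and adds a ring nitrogen at once, so the two changes cannot be told apart; a plain phenyl group at this position would help separate them. Pyridin-4-yl would show whether the place of the ring nitrogen matters.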